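A few compounds are considered here, and "the series" means these few. Any claim that something is new, unique, unknown or untested is made for them only; others in the source may bear on it.

Working notes on the series. Compound 1 `N#Cc1ccc(NCCNc2ncc(-c3ncc[nH]3)c(-c3ccc(Cl)cc3Cl)n2)nc1` was run in an ADME assay on microsomes from liver (Canis lupus familiaris) for metabolic stability; on this read-out higher numbers stand for a longer-lived compound and lower numbers for a shorter-lived compound. In this assay compound 1 reaches only a limit of the assay, > 0.5 h. Compound 2 `FC(F)(F)c1ccc(NCCNc2ncc(-c3ncc[nH]3)c(-c3ccc(Cl)cc3Cl)n2)nc1` carries trifluoromethyl in place of cyano on an aromatic carbon, and in this assay compound 2 likewise sits at a limit, > 0.5 h. The step that the two limits leave unreadable from compound 1 to compound 2 is therefore unreadable. Compound 3 `Nc1nc(NCCNc2ncc(-c3ncc[nH]3)c(-c3cc(F)ccc3Cl)n2)ccc1[N+](=O)[O-]` in this assay also gives a limit rather than a number, > 0.5 h. Compound 3 thus stands where every measured value stands, at the limit of > 0.5 h in this assay, at which 3 of the 3 values shown sit. Compound 4 `Cc1ccc(-c2nc(NCCNc3ccc([N+](=O)[O-])c(N)n3)ncc2-c2ncc[nH]2)c(Br)c1` differs from compound 3 in one place: 2-bromo-4-methylphenyl in place of 2-chloro-5-fluorophenyl on an aromatic carbon. For the measured compounds named here, no measured step involves this change, and the only step recorded has no readable size, so no shift beyond the scatter is expected in this assay. Compound 4 is therefore estimated to sit at about the same level, with the step that the limit leaves unreadable from compound 3 to compound 4 expected to be small. In this assay compound 4 is expected at 1 h, within 0.3 h to 3 h, most likely reported again only as a limit.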

Compound 4, half-life: > 0.5 h
Compound 4: no number, only a limit; the forecaster's own chance of this, stated with the estimate: 70%; the middle value does not contradict the limit.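

Compound 3 and compound 4 each give only a limit of the assay, so the step between them cannot be read. The compounds shown leave open the actual half-lives in this assay and whether any of these changes shifts them: the limit of > 0.5 h in this assay, at which 4 of the 4 values shown sit.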